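Methoxy for ethylamino beside the amide of compound 1

This account rests on a few compounds, and the source may have more. Where it says the series, first, only, none or still open, it means among the compounds named here.

Measured compounds:
compound 1 `CCNc1cc(-c2cccnc2)ccc1C(N)=O`, 58000 nM
compound 2 `Nc1snnc1-c1ccc(C(F)(F)F)cc1`, 50000 nM
compound 3 `CNC(=O)c1cncc(-c2ccc(C(N)=O)c(OC(C)C)c2)c1`, 1900 nM

In an assay on cells for inhibition of MAP kinase-interacting serine/threonine-protein kinase 1 (Homo sapiens), read by mobility shift assay, with stated times of 10 min and 60 min, in the presence of a further agent that is not named here (a lower number here means a stronger inhibitor, a higher number a weaker inhibitor), compound 1 gives the highest of the three numbers, so it is the weakest inhibitor shown. Compound 2 lies close to it, and the two cannot be told apart within the scatter. Compound 3 stands far lower, beyond the scatter, but it differs from compound 1 in more than one place, so no single step can be read from that pair.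

Compound 4 `COc1cc(-c2cccnc2)ccc1C(N)=O` is not yet measured. It changes compound 1 in one place: methoxy in place of ethylamino on an aromatic carbon. Nothing measured here isolates that change, so the expected step is small. The estimate is that the step from compound 1 to compound 4 in this assay is a 1.0-fold higher number from compound 1 to compound 4 (0.01 log units; within the scatter), well within the scatter in either direction. On that basis compound 4 is expected to give about 60000 nM, with a plausible range from 20000 nM to 150000 nM.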

Compound 4, half-maximal inhibitory concentration: 2800 nM
Compound 4: the middle estimate sits 21-fold (1.33 log units) above what was measured; measured number below the stated range.
By their numbers in this assay, from the lowest: compounds 3 and 4 (each within the scatter of the next); then compounds 2 and 1 (each within the scatter of the next).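

In this assay, methoxy in place of ethylamino, ortho to the carbamoyl group, gives a 21-fold lower number from compound 1 to compound 4 (1.32 log units; beyond the scatter), so with the rest of the molecule unchanged, this one position has a large bearing on the number. The swap changes more than one thing at once: the linking nitrogen becomes oxygen, the group loses a heavy atom, and the hydrogen-bond donor count falls from 1 to 0. Nothing available here explains the size of this step or shows which of those differences matters.

From the compounds shown here alone, it remains open whether the linking atom or the length of the chain matters more. An ethoxy group or a methylamino group on the same carbon would begin to separate the two, and a plain amine would show what the smallest nitrogen group does there.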